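A few compounds are considered here, and "the series" means these few. Any claim that something is new, unique, unknown or untested is made for them only; others in the source may bear on it.

Two compounds from one study have numbers in a functional assay on SW1573 cells (Homo sapiens) for inhibition, read by sulforhodamine B assay, with a stated time of 48 h; on this read-out lower numbers stand for stronger inhibition of growth and higher numbers for weaker inhibition of growth. Compound 1 `COC(=O)[C@@]1(C)CCC=C2[C@@H]1CC[C@@H](C)[C@]2(C)Cc1c(C)[nH]c2ccc(Br)cc12` gives 14000 nM in this assay. Compound 2 `COC(=O)[C@@]1(C)CC[C@@H]2C3=C1CC[C@@H](C)[C@]3(C)C[C@@H]1c3cc(Br)ccc3N[C@H]21` gives 45000 nM in this assay, the highest of the two numbers, so its inhibition of growth is weaker than that of compound 1, and the gap between them is beyond the usual scatter. Compound 3 `COC(=O)[C@@]1(C)CC[C@@H]2C3=C1CC[C@@H](C)[C@]3(C)C[C@@H]1c3cc(OC)ccc3N[C@H]21` has not yet been measured. It differs from compound 2 in one place: methoxy in place of bromo on an aromatic carbon. Going by the values given here, no measured pair in this set differs in one place only, so no measured step shows what such a swap tends to do here. The change is expected to move the number only a little, with a slight lean toward a higher number. The expected step is a 1.3-fold higher number from compound 2 to compound 3 (0.12 log units; within the scatter). On that basis compound 3 is estimated to give 60000 nM in this assay, most likely between 20000 nM and 150000 nM.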

Compound 3, concentration for 50% growth inhibition: 25000 nM
Compound 3: middle estimate off by 2.4-fold (0.38 log units), on the high side; the range from low to high includes it.
By their numbers in this assay, from the lowest: compounds 1, 3 and 2 (each within the scatter of the next, the first and the last beyond it).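

Putting methoxy in place of bromo on this aromatic carbon gives a 1.8-fold lower number from compound 2 to compound 3 (0.26 log units; within the scatter) in this assay, so the two groups cannot be told apart here. Going by these compounds alone, this is the first pair in the set that differs in one place only, and it gives a direct reading for this position: the exchange of a bromine for a group carrying a hydrogen-bond acceptor leaves the number within the usual scatter. Nothing available explains this outcome.

The compounds shown hold only bromo and methoxy at this carbon, so it remains open whether an amine, a carboxylic acid or a longer chain such as ethoxy would move the number beyond the scatter. Going by these compounds, it also remains open whether the same swap would behave alike on the core of compound 1, which carries bromo too.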